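Swapping the methylphenyl amide for a nitrophenyl amide

The source may report more compounds than this note shows. Statements on the series, on what has been measured and on what is new or still open speak of the compounds shown alone.

Compound 1 `COc1cc(OCC(=O)Nc2cccc(NC(=O)c3ccc(N(C)C)cc3)c2)ccc1C=O`: 306 nM
Compound 2 `CN(C)c1ccc(C(=O)Nc2cccc(NC(=O)COc3ccc4c(c3)OCCO4)c2)cc1`: > 10000 nM
Compound 3 `Cc1ccc(C(=O)Nc2cccc(NC(=O)COc3ccc4c(=O)ccoc4c3)c2)cc1`: 22 nM

In an assay on isolated protein for inhibition of Rho-associated protein kinase 2 (Homo sapiens), read by scintillation counting, radiometric assay and 33P incorporation, with a stated time of 40 min, in the presence of a further agent that is not named here (on this read-out lower numbers stand for stronger inhibition and higher numbers for weaker inhibition), compound 3 gives the lowest number of the two that were read, with compound 1 giving 306 nM as its nearest neighbour. Compound 2 returned only a limit in this assay, (the limit of > 10000 nM in this assay, at which 1 of the 3 values shown sits). Compound 4 `O=C(COc1ccc2c(=O)ccoc2c1)Nc1cccc(NC(=O)c2cccc([N+](=O)[O-])c2)c1` differs from compound 3 by 3-nitrophenyl in place of 4-methylphenyl on a carbonyl carbon. Among the measured compounds shown here, the one measured step, an at least 32-fold higher number from compound 1 to compound 2 (1.51 log units; beyond the scatter), changes the group on the oxygen on a saturated carbon, a different place, so it says nothing direct about the amide side. With no guide, compound 4 is expected to stay close to compound 3, as a step of a 1.8-fold higher number from compound 3 to compound 4 (0.26 log units; within the scatter). The estimate for compound 4 in this assay is 40 nM, between 10 nM and 160 nM.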

Compound 4, half-maximal inhibitory concentration: 41 nM
Estimate against measurement, compound 4: 1.0-fold (0.01 log units) below, within the range that was stated.
By their numbers in this assay, from the lowest: compounds 3 and 4 (each within the scatter of the next); then compound 1. At a limit, above all of these: compound 2.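

Swapping 4-methylphenyl for 3-nitrophenyl on a carbonyl carbon gives the first measured step on the amide side of these molecules. The step is a 1.9-fold higher number from compound 3 to compound 4 (0.27 log units; within the scatter) and so does not separate the two compounds, even though the entering group counts 2 hydrogen-bond acceptors and the leaving group none. Nothing measured here accounts for this result. Going by these compounds, whether a ring carrying an amine or a carboxylic acid on this carbonyl carbon would read the same remains open.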